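Lengthening the Chain on the Shared Core

The source may report more compounds than this note shows. Statements on the series, on what has been measured and on what is new or still open speak of the compounds shown alone.

Measured compounds:
Compound 1, `CCCn1c(N2CCN(C)CC2)nc2ccccc21`, gives 380 nM in a functional assay on ileum for inhibition of histamine H1 receptor (Cavia porcellus); a higher number here means a weaker inhibitor, a lower number a stronger inhibitor.
Compound 2, `CCCCOCCn1c(N2CCN(C)CC2)nc2ccccc21`, gives 38 nM in this assay.
Compound 3, `CCSCCCn1c(N2CCN(C)CC2)nc2ccccc21`, gives 530 nM in this assay.

Compound 3 holds the highest of the three numbers. Its nearest neighbour is compound 1: a 1.4-fold higher number from compound 1 to compound 3 (0.14 log units; within the scatter), so these two cannot be told apart. Its furthest is compound 2: a 14-fold higher number from compound 2 to compound 3 (1.14 log units; beyond the scatter), a clear gap.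

Compound 4, `CCCCCCCCCCn1c(N2CCN(C)CC2)nc2ccccc21`, has not yet been measured. The change from compound 3 is heptyl in place of ethylsulfanyl on a saturated chain carbon, three bonds along the chain from an aromatic nitrogen. Among the measured compounds shown here, three steps bear on it. The step of a 10-fold lower number from compound 1 to compound 2 (1.00 log units; beyond the scatter) shows that a longer chain carrying an oxygen can lower the number considerably. The step of a 1.4-fold higher number from compound 1 to compound 3 (0.14 log units; within the scatter) shows that adding ethylsulfanyl changed nothing beyond the scatter, and a 14-fold higher number from compound 2 to compound 3 (1.14 log units; beyond the scatter) shows how far apart those two chain ends lie. For the measured compounds named here, no measured step tests a plain long chain with no heteroatom, so the direction is uncertain; a modest lowering is expected, reading as a 2.7-fold lower number from compound 3 to compound 4 (0.42 log units; beyond the scatter). Compound 4 is therefore estimated at 200 nM, with a range from 50 nM to 800 nM.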

Compound 4, half-maximal inhibitory concentration: 4200 nM
The estimate for compound 4 lay 21-fold (1.32 log units) below the measured number, outside the stated range (above it).
By their numbers in this assay, from the lowest: compound 2; then compounds 1 and 3 (each within the scatter of the next); then compound 4.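

In this assay, heptyl in place of hydrogen on a saturated chain carbon, three bonds along the chain from an aromatic nitrogen, gives an 11-fold higher number from compound 1 to compound 4 (1.04 log units; beyond the scatter) and so shows that lengthening the chain at this position need not lower the number. Heptyl in place of ethylsulfanyl gives a 7.9-fold higher number from compound 3 to compound 4 (0.90 log units; beyond the scatter) while octyl in place of butoxy gives a 110-fold higher number from compound 2 to compound 4 (2.04 log units; beyond the scatter) and sets compound 2 and compound 4, both with longer chains than compound 1, on opposite sides of it. No measurement shown here accounts for this reversal.

Compound 2 and compound 4 differ in both chain length and the oxygen, so the compounds shown cannot separate these two changes. On these data alone, whether a plain hexyl chain or a chain ending in a hydroxyl or an amine would fall nearer compound 2 or compound 4 remains open.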